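The compounds below may be only part of what the source reports. "The series", "measured", "known", "first", "only" and "open" are said of these compounds alone.

Measured compounds:
- compound 1, `CC1(C)C=C(n2ccccc2=O)c2cc(C(=O)c3ccccc3F)ccc2O1`: 6.34
- compound 2, `CC1(C)C=C(n2ccccc2=O)c2cc(C=O)ccc2O1`: 6.14
- compound 3, `CC1(C)C=C(n2ccccc2=O)c2cc(OCC(=O)c3ccccc3)ccc2O1`: 4.69

In a functional assay (trachea) with Rattus norvegicus as the target (on this read-out higher numbers stand for higher potency (the scale is a negative logarithm) and lower numbers for lower potency), compound 3 stands lowest of the three, with compound 2 nearest and compound 1 furthest, both gaps beyond the scatter. Compound 4, `CC1(C)C=C(n2ccccc2=O)c2cc(OC(=O)Nc3ccc(F)cc3)ccc2O1`, differs from compound 3 at one place: (4-fluorophenyl)carbamoyl in place of benzoylmethyl on an oxygen on an aromatic ring. For the measured compounds named here, the only measured step, a number 0.20 log units lower from compound 1 to compound 2 (within the scatter), concerns a carbonyl carbon and lies within the scatter, so no measured step bears directly on an exchange of a group on the aromatic oxygen. Compound 1 and compound 2 show that substituents on the carbonyl carbon leave the number much the same, while compound 3 with its benzoylmethyl on the oxygen falls well below both. Without a comparable step, the expectation for compound 4 rests mainly on its closeness to compound 3, with a wide range. Compound 4 is therefore expected near 4.9, between 4.1 and 5.8. The estimated step of a number 0.21 log units higher from compound 3 to compound 4 (within the scatter) is expected to stay within the scatter.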

Compound 4, logarithm of the reciprocal of the active concentration, log(1/C): 4.37
Compound 4: the middle estimate sits 0.53 log units above what was measured; the range from low to high includes it.
By their numbers in this assay, from the lowest: compound 4; then compound 3; then compounds 2 and 1 (each within the scatter of the next).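

In this assay, the exchange of benzoylmethyl for (4-fluorophenyl)carbamoyl on an oxygen on an aromatic ring gives a number 0.32 log units lower from compound 3 to compound 4 (beyond the scatter). For the compounds shown here, this is the first measured step at this place, and it shows that the number here responds to the group on the oxygen, with the entering group bringing a hydrogen-bond donor that benzoylmethyl lacks. Both oxygen-linked compounds also stand well apart from the carbonyl-linked ones, with compound 4 at 4.37 and compound 2 at 6.14, but nothing on hand explains the step.

The compounds shown leave open how much of the step belongs to the fluorine and how much to the carbamoyl link, a question that the plain phenylcarbamoyl group would address. They also leave open whether a methyl group or a bare hydroxyl on this oxygen would stand nearer compound 2.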